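From Pentyl to 2-(Benzyloxy)ethyl on the Shared Core

This account rests on a few compounds, and the source may have more. Where it says the series, first, only, none or still open, it means among the compounds named here.

In an ADME assay on microsomes from liver (Mus musculus) for metabolic stability, read by LC-MS, using NADPH, with stated times of 15 min and 60 min, tested at 4.6 uM (on this read-out lower numbers stand for a shorter-lived compound and higher numbers for a longer-lived compound), compound 3 `CCCCCNC(=O)n1c(=O)oc2cc(C3CCN(C)CC3)ccc21` has no exact number, only > 1 h, which is a limit. This is the limit of > 1 h in this assay, at which 1 of the 3 values shown sits. Compound 1 `CN1CCC(c2ccc3c(c2)oc(=O)n3C(=O)NCCCCc2ccc(F)cc2)CC1` gives 0.5 h, and compound 2 `CN1CCC(c2ccc3c(c2)oc(=O)n3C(=O)NCCCCc2ccccc2)CC1` gives 0.667 h, with a 1.3-fold higher number from compound 1 to compound 2 (0.13 log units; within the scatter).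

Compound 4 `CN1CCC(c2ccc3c(c2)oc(=O)n3C(=O)NCCOCc2ccccc2)CC1` has benzyloxy in place of propyl on a saturated chain carbon, two bonds along the chain from an amide-type nitrogen. The same difference reads pentyl to 2-(benzyloxy)ethyl, and it brings in one six-membered aromatic ring of carbon only.

The closest measured comparisons are an at least 2.0-fold higher number from compound 1 to compound 3 (0.30 log units; that floor lies within the scatter) and an at least 1.4-fold higher number from compound 2 to compound 3 (0.17 log units; that floor lies within the scatter). Both end at the ring-free chain of compound 3, so the change to compound 4 runs the opposite way. A modest drop in this assay is therefore expected, perhaps hardly beyond the scatter, and compound 4 should lie near compound 2 at 0.667 h. The expected change is an at least 1.8-fold lower number from compound 3 to compound 4 (0.25 log units; that floor lies within the scatter). Compound 4 is estimated at 0.55 h, with an expected range of 0.27 h to 1.1 h.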

Compound 4, half-life: 0.5 h
Compound 4: the middle estimate sits 1.1-fold (0.04 log units) above what was measured; measured number inside the range.
By their numbers in this assay, from the lowest: compounds 1, 4 and 2 (each within the scatter of the next). At a limit, above all of these: compound 3.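

In this assay, a chain oxygen leaves the ring-bearing compounds together, as the benzyloxy chain differs little from the all-carbon chains: a 1.3-fold lower number from compound 2 to compound 4 (0.13 log units; within the scatter), and no change at the digits printed from compound 1 to compound 4 (within the scatter). Set against the ring-free pentyl chain, the 2-(benzyloxy)ethyl chain gives an at least 2.0-fold lower number from compound 3 to compound 4 (0.30 log units; that floor lies within the scatter). Compound 3 stands at a limit, so the size of this step is known only as a floor: the limit of > 1 h in this assay, at which 1 of the 4 values shown sits.

The compounds shown leave open whether a ring-free ether chain such as 2-methoxyethyl would read like compound 3 or like compound 4, so the effects of the ring and the oxygen cannot be told apart. They also leave open how an amine at the end of the chain would read in this assay.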